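This account rests on a few compounds, and the source may have more. Where it says the series, first, only, none or still open, it means among the compounds named here.

Working notes on the substituent on the amino nitrogen. In an ADME assay on MT4 cells (Homo sapiens) for cytotoxicity, read by MTT assay, with a stated time of 5 days (on this read-out higher numbers stand for lower toxicity in this test and lower numbers for higher toxicity in this test), compound 2 `CCCNc1cc(Oc2c(OC)cc3cc(C#N)ccc3c2OC)nc(Nc2ccc(C#N)cc2)n1` gives > 125000 nM, which is a limit and not a number. Compound 3 `COc1cc2cc(C#N)ccc2c(OC)c1Oc1cc(NC(C)C)nc(Nc2ccc(C#N)cc2)n1` gives > 125000 nM, likewise a limit. Compound 2 therefore stands at the limit of > 125000 nM in this assay, at which 2 of the 3 values shown sit. Among the compounds with values here, the only actual number in the set belongs to compound 1 `CNc1cc(Oc2c(OC)cc3cc(C#N)ccc3c2OC)nc(Nc2ccc(C#N)cc2)n1`, which gives 239000 nM.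

The next compound is compound 4 `COc1cc2cc(C#N)ccc2c(OC)c1Oc1cc(NC(C)(C)C)nc(Nc2ccc(C#N)cc2)n1`, reached from compound 2 by the change (tert-butyl in place of propyl on a nitrogen on an aromatic ring), that is, tert-butyl in place of propyl on a nitrogen on an aromatic ring. The measured steps that bear on this change all alter the same substituent: a step that the limit leaves unreadable from compound 1 to compound 2, a step that the limit leaves unreadable from compound 1 to compound 3 and a step that the two limits leave unreadable from compound 2 to compound 3. None of them has a size that can be read, so they offer no measured trend to carry forward. No step beyond the usual scatter is therefore expected in this assay, in either direction. The expected step is a step that the limit leaves unreadable from compound 2 to compound 4. Within the data shown here, this expectation rests on compound 1 at 239000 nM, the one number available. A further limit is the likeliest report. The estimate for compound 4 is 200000 nM, with an expected range from 110000 nM to 350000 nM.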

Compound 4, half-maximal cytotoxic concentration: > 125000 nM
Compound 4 ended at the assay's limit; the forecaster's own chance of this, stated with the estimate: 70%; the middle value is on the limit's open side.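

In this assay compound 4 gives > 125000 nM, a limit and not a number, and none of its steps to compound 1, compound 2 or compound 3 can be read. The compounds shown leave open where the actual values of compound 2, compound 3 and compound 4 lie, and whether the substituent on the amino nitrogen alters this read-out at all.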